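The source may hold more compounds than are shown below. What is called first, only, known or untested is meant among the compounds shown, and "the series" means these compounds.

Two esters built on the shared core have been tested in a functional assay on PRK cells (Oryctolagus cuniculus) for cytotoxicity; on this read-out lower numbers stand for higher toxicity in this test and higher numbers for lower toxicity in this test. Compound 1 `CC(C)(C)OC(=O)C(O)Cn1cnc2c(N)ncnc21` carries a tert-butyl group on an oxygen next to a carbonyl group; in this assay compound 1 gives > 400 ug/mL, which is a limit of the test rather than a number. Compound 2 `CCC(C)OC(=O)C(O)Cn1cnc2c(N)ncnc21` has sec-butyl in place of tert-butyl on an oxygen next to a carbonyl group; in this assay compound 2 also gives > 400 ug/mL, again a limit. The step that the two limits leave unreadable from compound 1 to compound 2 therefore cannot be read, and compound 2 stands where every measured value stands, namely at the limit of > 400 ug/mL in this assay, at which 2 of the 2 values shown sit. Compound 3 `COC(=O)C(O)Cn1cnc2c(N)ncnc21` is the next ester in the row: methyl in place of sec-butyl on an oxygen next to a carbonyl group. Among the measured compounds shown here, the only measured step, a step that the two limits leave unreadable from compound 1 to compound 2, has a size hidden by the two limits, so nothing seen so far points to a shift in either direction beyond the scatter, and the most the data allow is a check whether the shortened ester stays at the same ceiling. For compound 3 the expectation in this assay is an estimated step of a number no higher from compound 2 to compound 3 (the limit leaves the size open) and an estimated value of 400 ug/mL, between 200 ug/mL and 800 ug/mL.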

Compound 3, minimum cytotoxic concentration: > 400 ug/mL
Compound 3 was reported as a limit; the forecaster's own chance of this, stated with the estimate: 85%; the middle value lies on the limit itself.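

In this assay, compound 3 ends at a limit of the test, as do compound 1 and compound 2, so none of the steps among these three compounds can be read: the limit of > 400 ug/mL in this assay, at which 3 of the 3 values shown sit. The compounds shown leave open whether the methyl, sec-butyl and tert-butyl esters differ from one another in this assay, and at what concentration each becomes toxic to the cells.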